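Swapping the Ring on the Fused Core for an Oxane

A few compounds are considered here, and "the series" means these few. Any claim that something is new, unique, unknown or untested is made for them only; others in the source may bear on it.

Measured compounds:
compound 1, `COc1cc(C(=O)N2CCCC2)ccc1-c1ccnc2[nH]c(C3CCOCC3)cc12`: 15 uL/min
compound 2, `COc1cc(F)ccc1-c1ccnc2[nH]c(C3CCN(C(C)=O)CC3)cc12`: 50 uL/min

Of the compounds shown here, two have been measured in an ADME assay on cells (Hepatocyte, Rattus norvegicus) for metabolic stability; on this read-out higher numbers stand for fast clearance and lower numbers for slow clearance. Compound 1 gives 15 uL/min in this assay. Compound 2 gives 50 uL/min in this assay, which is the higher of the two numbers, and the gap to compound 1 lies beyond the usual scatter. Among the measured compounds shown here, the two compounds differ in more than one place, so no single step between them is available.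

Compound 3, `COc1cc(F)ccc1-c1ccnc2[nH]c(C3CCOCC3)cc12`, has not been measured. For the measured compounds named here, it keeps the shared core and the fluorine-bearing side of compound 2 and changes only one group: oxan-4-yl in place of 1-acetylpiperidin-4-yl on an aromatic carbon. Going by the values given here, the group that enters is the one present in compound 1, the slower-cleared of the two measured compounds, though compound 1 also carries a different group on its other ring, so the comparison is indirect.

On this basis a step downward is expected, of modest size, when going a 2.0-fold lower number from compound 2 to compound 3 (0.30 log units; within the scatter). Compound 3 is expected to give about 25 uL/min, within a range from 12 uL/min to 50 uL/min.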

Compound 3, intrinsic clearance in a liver preparation (reported as CLH), per the amount of preparation that the assay uses in the Hepatocyte assay: 97 uL/min
The estimate for compound 3 lay 3.9-fold (0.59 log units) below the measured number, outside the stated range (above it).
By their numbers in the Hepatocyte assay, from the lowest: compound 1; then compounds 2 and 3 (each within the scatter of the next).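

At this position the ring exchange does not carry the clearance with it: in the Hepatocyte assay the oxan-4-yl group in place of 1-acetylpiperidin-4-yl gives a 1.9-fold higher number from compound 2 to compound 3 (0.29 log units; within the scatter), so on this read-out the two groups cannot be told apart. With oxan-4-yl held fixed, the difference appears at the other place, where fluoro in place of (pyrrolidin-1-yl)carbonyl gives a 6.5-fold higher number from compound 1 to compound 3 (0.81 log units; beyond the scatter), so the low number of compound 1 goes with its (pyrrolidin-1-yl)carbonyl group and not with the oxane. In a physicochemical assay for lipophilicity, using the shake flask method, measured as octanol-water partition, at pH 7.4 (a lower number here means a more polar compound, a higher number a more lipophilic compound), compound 2 gives 3.4 and compound 3 gives 3.9, so the same exchange does register in lipophilicity even though its step in clearance stays within the scatter: the measured distribution coefficient of compound 2, 3.4, and of compound 3, 3.9, a number 0.50 log units higher (beyond the scatter)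

A single pair cannot show whether the numbers in the Hepatocyte assay follow the distribution coefficient across this series, and the pair of compound 2 and compound 3 alone cannot settle it. Also open, on these data alone, is how an amine or a carboxylic acid on the same aromatic carbon would behave, and whether 1-acetylpiperidin-4-yl and oxan-4-yl would still match when paired with the (pyrrolidin-1-yl)carbonyl group.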